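This account rests on a few compounds, and the source may have more. Where it says the series, first, only, none or still open, it means among the compounds named here.

In a functional assay on the whole organism with Mus musculus as the target, in the rotarod test (on this read-out higher numbers stand for an effect only at larger amounts of compound and lower numbers for an effect already at smaller amounts), compound 1 (`CC(C)NCC(=O)NCC(=O)N(C)c1ccc(Cl)cc1C(=O)c1ccccc1Cl`) gives 13 mg/kg. Compound 2 (`NCC(=O)NCC(=O)Nc1ccc([N+](=O)[O-])cc1C(=O)c1ccccc1`) gives 24.8 mg/kg, so the two stand within the usual scatter of each other. Compound 3 (`CCCC(=O)NCC(=O)N(C)c1ccc(Cl)cc1C(=O)c1ccccc1Cl`) has not yet been measured. It departs from compound 1 with ethyl in place of isopropylamino on a saturated chain carbon bound to a carbonyl carbon. Among the measured compounds shown here, no measured step shows what such a change does, so the expectation is only tentative. The expected step is a 6.2-fold higher number from compound 1 to compound 3 (0.79 log units; beyond the scatter), towards larger amounts in this assay. For compound 3 the estimate is 80 mg/kg, with an expected range of 25 mg/kg to 300 mg/kg.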

Compound 3, dose for half-maximal effect: 55.2 mg/kg
For compound 3 the middle estimate is 1.4-fold (0.16 log units) above the measured one, and the stated range covers the measured number.
By their numbers in this assay, from the lowest: compounds 1 and 2 (each within the scatter of the next); then compound 3.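

In this assay ethyl in place of isopropylamino on a saturated chain carbon bound to a carbonyl carbon brings a 4.2-fold higher number from compound 1 to compound 3 (0.63 log units; beyond the scatter) and thus gives the first measured sign that this position is sensitive to the group it carries. The step is modest, and with compound 3 the effect appears only at larger amounts. No measurement shown here accounts for this step.

This one step cannot separate the loss of the nitrogen from the loss of the branched carbons. As far as these compounds go, how a dimethylamino group, a morpholine ring or a butyl chain would fare at this place remains open.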